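A Methoxy for a Methyl on a Shared Core

The source may hold more compounds than are shown below. What is called first, only, known or untested is meant among the compounds shown, and "the series" means these compounds.

Compound 1 `CC(C)=CCOc1c(C)c(C)c2c(c1C)CCC(C)(COc1ccc(/C=C3\SC(=O)NC3=O)cc1C)O2`: 27%
Compound 2 `Cc1c(C)c2c(c(C)c1OC(=O)CCC(=O)O)CCC(C)(COc1ccc(/C=C3\SC(=O)NC3=O)cc1)O2`: 76%
Compound 3 `Cc1c(C)c2c(c(C)c1OC/C=C/c1ccccc1)CCC(C)(COc1ccc(/C=C3\SC(=O)NC3=O)cc1)O2`: 43%

In a functional assay on MCF7 cells (Homo sapiens), tested at 7.5 uM (a higher number here means a weaker effect of the compound at the concentration tested, a lower number a stronger effect), compound 1 gives 27%, the lowest of the three numbers and therefore the strongest effect in this set. Compound 3 comes nearest, its number higher by more than the scatter, and compound 2 lies furthest, also beyond the scatter.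

Compound 4 `COc1cc(/C=C2\SC(=O)NC2=O)ccc1OCC1(C)CCc2c(C)c(OCC=C(C)C)c(C)c(C)c2O1` is the unmeasured member. It differs from compound 1 by methoxy in place of methyl on an aromatic carbon.

Among the measured compounds shown here, the one measured step that changes a single group, a number 33 percentage points lower from compound 2 to compound 3 (beyond the scatter), swaps the group on an oxygen of the shared core. For the measured compounds named here, it says nothing about a methyl or methoxy on the other aromatic ring, so no measured step bears on the change from compound 1 to compound 4. With no guidance, a step of a number 3 percentage points higher from compound 1 to compound 4 (within the scatter) is expected, that is, none beyond the scatter. Compound 4 is therefore estimated at 30%, in a range from 15% to 50%.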

Compound 4, a percentage reported as activity, at one concentration (the size of the read-out at that concentration, not a potency): 54%
Beside the measured number, compound 4's estimate is 24 percentage points below it; the whole stated range lies below it.
By their numbers in this assay, from the lowest: compound 1; then compound 3; then compound 4; then compound 2.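

Methoxy in place of methyl on this aromatic carbon, ortho to a large group, is not a neutral swap: this assay gives a number 27 percentage points higher from compound 1 to compound 4 (beyond the scatter), and a higher number here means a weaker effect. Among the compounds shown here, the earlier step changed only the group on an oxygen of the shared core, so this is the first sign that the other aromatic ring also affects the read-out. Nothing available here explains why this small change, which adds one oxygen, weakens the effect.

Going by these compounds, whether a group such as ethoxy, hydroxyl or chlorine on this carbon would stay close to methyl or fall closer to methoxy remains open. It is also unknown whether the same swap would weaken the effect as much with a 3-phenylprop-2-en-1-yl group on the core's oxygen.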